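A few compounds are considered here, and "the series" means these few. Any claim that something is new, unique, unknown or untested is made for them only; others in the source may bear on it.

Compound 1, whose structure is `O=c1cc(/C=N\c2ccccc2O)c2ccc(OCc3ccccc3)cc2o1`, is the starting point of this piece. In a functional assay, read by spectrophotometry, with a stated time of 5 min (a lower number here means a stronger inhibitor, a higher number a weaker inhibitor), compound 1 gives 469000 nM, the highest of the two plain numbers measured here. Its nearest neighbour among the measured compounds is compound 3, with structure `O=c1cc(/C=N\Nc2ccccc2)c2c(OCc3ccccc3)cc(OCc3ccccc3)cc2o1`, which in this assay gives 303000 nM; that gap lies within the usual scatter, so the two compounds cannot be ranked against each other. Compound 2, with structure `O=c1cc(/C=N\O)c2c(OCc3ccccc3)cc(OCc3ccccc3)cc2o1`, is reported in this assay only as a limit, > 2000000 nM, not as a number (the limit of > 2000000 nM in this assay, at which 1 of the 3 values shown sits). Going by the values given here, the one measured step with a known size is an at least 6.6-fold lower number from compound 2 to compound 3 (0.81 log units; beyond the scatter); it changes the group on the double-bonded nitrogen, but it swaps hydroxy for anilino rather than moving a hydroxy around a phenyl ring, so it speaks only distantly to the change at hand.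

Compound 4, with structure `O=c1cc(/C=N\c2ccc(O)cc2)c2ccc(OCc3ccccc3)cc2o1`, has not yet been measured. It differs from compound 1 as follows: 4-hydroxyphenyl in place of 2-hydroxyphenyl on a double-bonded nitrogen. Among the compounds with values here, no measured pair here shows a hydroxy moving from one position of the phenyl to another, so no step beyond the scatter is expected in either direction. Compound 4 is therefore estimated to give about 469000 nM in this assay, somewhere between 150000 nM and 1500000 nM; the step of no change at the digits printed from compound 1 to compound 4 (within the scatter) is expected to stay within the scatter.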

Compound 4, half-maximal inhibitory concentration: 525000 nM
The estimate for compound 4 lay 1.1-fold (0.05 log units) below the measured number; measured number inside the range.
By their numbers in this assay, from the lowest: compounds 3, 1 and 4 (each within the scatter of the next). At a limit, above all of these: compound 2.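

Setting 4-hydroxyphenyl in place of 2-hydroxyphenyl on the double-bonded nitrogen gives a 1.1-fold higher number from compound 1 to compound 4 (0.05 log units; within the scatter), so in this assay this swap produces no difference that can be told apart from the usual scatter. Going by these compounds alone, the earlier step replaced the whole group on that nitrogen, whereas this pair is the first direct test of where the hydroxy sits on the phenyl, and for these two placements the read-out does not separate them. No measurement shown here bears on why the two compounds cannot be separated.

The compounds shown leave open whether the hydroxy itself counts for anything, since both members of this pair carry one: a plain phenyl, or a phenyl bearing a methoxy, an amine or a carboxylic acid instead, might give a number that stands clear of the scatter or might not. They also leave open whether the same swap would read the same way on a different core, as this single pair speaks only for the core of compound 1.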